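Aryl variation on the aromatic nitrogen of the shared core

A few compounds are considered here, and "the series" means these few. Any claim that something is new, unique, unknown or untested is made for them only; others in the source may bear on it.

Compound 1 `N#CC1=C(N)Oc2c(c3nc4ccccc4nc3c3ccccc23)C12C(=O)N(Cc1cnnn1-c1ccccc1Cl)c1ccccc12`: in a functional assay on A549 cells (Homo sapiens) for antiproliferative activity, read by MTT assay, with a stated time of 48 h (on this read-out higher numbers stand for weaker inhibition and lower numbers for stronger inhibition), compound 1 gives 42600 nM.
Compound 2 `N#CC1=C(N)Oc2c(c3nc4ccccc4nc3c3ccccc23)C12C(=O)N(Cc1cnnn1-c1cccc(Br)c1)c1ccccc12`: in this assay compound 2 reaches only the assay limit, > 50000 nM.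
Compound 3 `N#CC1=C(N)Oc2c(c3nc4ccccc4nc3c3ccccc23)C12C(=O)N(Cc1cnnn1-c1ccc(S(N)(=O)=O)cc1)c1ccccc12`: in this assay compound 3 likewise reaches only the assay limit, > 50000 nM.

Compound 3 thus stands at the limit, without a number, as the limit of > 50000 nM in this assay, at which 2 of the 3 values shown sit, records; compound 1 alone gives a readable value. Compound 4 `Cc1ccc(-n2nncc2CN2C(=O)C3(C(C#N)=C(N)Oc4c3c3nc5ccccc5nc3c3ccccc43)c3ccccc32)cc1Cl` is not yet measured; the change is 3-chloro-4-methylphenyl in place of 4-sulfamoylphenyl on an aromatic nitrogen. The steps bearing on it are an at least 1.1-fold higher number from compound 1 to compound 2 (0.06 log units; that floor lies within the scatter) and an at least 1.1-fold higher number from compound 1 to compound 3 (0.06 log units; that floor lies within the scatter), both within the scatter, while a step that the two limits leave unreadable from compound 2 to compound 3. No step beyond the scatter is therefore expected for compound 4 in this assay. Compound 4 is estimated at 50000 nM (range 30000 nM to 100000 nM), most likely again only a limit, an expected step of a number no higher from compound 3 to compound 4 (the limit leaves the size open).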

Compound 4, half-maximal inhibitory concentration: > 50000 nM
Compound 4 ended at the assay's limit; the forecaster's own chance of this, stated with the estimate: 60%; the middle value lies on the limit itself.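

In this assay, 3-chloro-4-methylphenyl, with 0 hydrogen-bond donors and 0 hydrogen-bond acceptors, leaves this aromatic nitrogen at the same assay limit as 4-sulfamoylphenyl, so neither group gives a readable value: the limit of > 50000 nM in this assay, at which 3 of the 4 values shown sit.

The steps among compound 2, compound 3 and compound 4 cannot be read. Among these compounds, the one readable comparison is an at least 1.1-fold higher number from compound 1 to compound 4 (0.06 log units; that floor lies within the scatter), so this floor does not set 3-chloro-4-methylphenyl apart from 2-chlorophenyl.

As far as these compounds go, whether an amine or a carboxylic acid on the phenyl ring would give a readable value in this assay stays open. From the compounds shown here alone, the true distance of compound 2, compound 3 and compound 4 from compound 1 also stays open.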